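Trading an acetyl for a methyl on the pyridine-like ring

A few compounds are considered here, and "the series" means these few. Any claim that something is new, unique, unknown or untested is made for them only; others in the source may bear on it.

Of the compounds shown here, two have been measured so far. Compound 1 `COc1cc(C#N)cc(C#Cc2cccc(C)n2)c1` gives 3.4 nM in an in vitro functional assay on HEK293-A cells for agonist activity at metabotropic glutamate receptor 5 (Rattus norvegicus), read by ELISA; on this read-out lower numbers stand for stronger inhibition and higher numbers for weaker inhibition. Compound 2 `CC(=O)c1cccc(C#Cc2cc(F)cc(C#N)c2)n1` gives 240 nM in this assay, which is the higher of the two numbers, and the gap between the two values lies well beyond the scatter of repeated measurements. The two compounds differ in more than one place, so no single step can be read from them.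

Compound 3 `Cc1cccc(C#Cc2cc(F)cc(C#N)c2)n1` has not yet been measured. It is compound 2 with one change: methyl in place of acetyl on an aromatic carbon. Going by the values given here, no pair of measured compounds shows this step by itself, so its size has to be guessed. Among the compounds with values here, compound 1, the only other measured compound, already carries the methyl that enters here and gives 3.4 nM in this assay, so a move toward lower numbers looks more likely than a move toward higher ones. The step from compound 2 to compound 3 is expected to be a clear drop, a 24-fold lower number from compound 2 to compound 3 (1.38 log units; beyond the scatter). Compound 3 is therefore estimated at 10 nM in this assay, with a plausible range from 2 nM to 60 nM.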

Compound 3, half-maximal inhibitory concentration: 2.4 nM
Estimate against measurement, compound 3: 4.2-fold (0.62 log units) above; measured number inside the range.
By their numbers in this assay, from the lowest: compounds 3 and 1 (each within the scatter of the next); then compound 2.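

With methyl in place of acetyl on the aromatic carbon next to the ring nitrogen, this assay shows a 100-fold lower number from compound 2 to compound 3 (2.00 log units; beyond the scatter), so this single position can shift the read-out by a large amount. The change takes away a group of 3 heavy atoms that holds a double bond and a hydrogen-bond acceptor and puts a single carbon there, so the step cannot separate the effect of size from that of the acceptor. With the methyl in place, fluoro in place of methoxy on an aromatic carbon gives a 1.4-fold lower number from compound 1 to compound 3 (0.15 log units; within the scatter), so this second change leaves no difference that can be told apart from the scatter of repeated measurements.

Nothing available here explains why the two groups differ so much at this position. On these data alone, it remains open whether an ethyl, a hydroxymethyl or a plain hydrogen at this position would stay with the methyl compounds or move toward the acetyl compound, and whether swapping fluoro for methoxy would stay as small with the acetyl present.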